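A Benzylsulfanyl Group Added to Compound 3

The compounds below may be only part of what the source reports. "The series", "measured", "known", "first", "only" and "open" are said of these compounds alone.

Of the compounds shown here, three have been measured in a functional assay on L1210 cells (Mus musculus) for inhibition; a higher number here means a weaker inhibitor, a lower number a stronger inhibitor: compound 1 `CCOC(=O)Nc1cc(N/N=C/c2ccccc2)c(N)c(N)n1` gives 4600 nM, compound 2 `CCOC(=O)Nc1cc2c(ncn2/N=C/c2ccccc2)c(N)n1` gives 150 nM, and compound 3 `CCOC(=O)Nc1cc(N/N=C/c2ccccc2)c2[nH]cnc2n1` gives 250 nM.

Compound 3 holds the second highest of the three numbers. Its nearest neighbour is compound 2, whose number lies within the scatter of its own, so the two cannot be told apart. Compound 1 sits far above it, beyond the scatter.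

Compound 4 `CCOC(=O)Nc1cc(N/N=C/c2ccccc2)c2[nH]c(SCc3ccccc3)nc2n1` differs from compound 3 in one place: benzylsulfanyl in place of hydrogen on an aromatic carbon. Going by the values given here, no measured pair in this set shows the effect of such a change, so the direction is open. The step from compound 3 to compound 4 in this assay is expected to be small, perhaps none beyond the scatter, as a 1.6-fold higher number from compound 3 to compound 4 (0.20 log units; within the scatter). Compound 4 is estimated at 400 nM, within 120 nM to 1500 nM.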

Compound 4, half-maximal inhibitory concentration: 46000 nM
Beside the measured number, compound 4's estimate is 120-fold (2.06 log units) below it; the whole stated range lies below it.
By their numbers in this assay, from the lowest: compounds 2 and 3 (each within the scatter of the next); then compound 1; then compound 4.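

With benzylsulfanyl in place of hydrogen on an aromatic carbon between two ring nitrogen atoms, this assay records a 180-fold higher number from compound 3 to compound 4 (2.26 log units; beyond the scatter) as a large loss of inhibition. Going by these compounds alone, this is the first sign that the position is sensitive, since the earlier compounds carried only hydrogen there. Nothing available accounts for the loss.

From the compounds shown here alone, whether it belongs to the whole benzylsulfanyl group, to its sulfur or to its aromatic ring remains open. A methyl group, an amine or methylsulfanyl on the same carbon would help separate these.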